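The source may hold more compounds than are shown below. What is called first, only, known or untested is meant among the compounds shown, and "the series" means these compounds.

The study concerns three measured compounds and one that remains to be measured, all sharing a core and differing only in the substituent on the anilide ring. Compound 1 is `O=C(Nc1ccc(F)cc1)c1cc(Cl)ccc1O`, compound 2 is `O=C(Nc1cccc(F)c1)c1cc(Cl)ccc1O`, compound 3 is `O=C(Nc1ccc(C(F)(F)F)cc1)c1cc(Cl)ccc1O`, and compound 4 is `O=C(Nc1cccc(C(F)(F)F)c1)c1cc(Cl)ccc1O`. In a toxicity assay on Vero C1008 cells (Chlorocebus sabaeus) for cytotoxicity, read by MTT assay, with a stated time of 48 h (a higher number here means that more compound is tolerated, a lower number that less compound is tolerated), compound 1 gives 6780 nM, compound 2 gives 3630 nM, and compound 3 gives 1180 nM. Between compound 1 and compound 3 the change is trifluoromethyl in place of fluoro on an aromatic carbon, and it produced a 5.7-fold lower number from compound 1 to compound 3 (0.76 log units; beyond the scatter). How the cores of compound 1 and compound 2 differ is not broken down here. Among the compounds with values here, the change from compound 2 to compound 4 is trifluoromethyl in place of fluoro on an aromatic carbon; it is the same kind of change as the one from compound 1 to compound 3, but its place differs, being meta to a large group rather than para to a large group. Because the earlier change gave a 5.7-fold lower number from compound 1 to compound 3 (0.76 log units; beyond the scatter), the author expects a step from compound 2 to compound 4 of about a 4.5-fold lower number from compound 2 to compound 4 (0.66 log units; beyond the scatter) in this assay. Compound 4 is thus estimated at 800 nM, with a range of 300 nM to 2200 nM.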

Compound 4, half-maximal cytotoxic concentration: 5950 nM
Estimate against measurement, compound 4: 7.4-fold (0.87 log units) below; measured number outside the range, above it.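

In this assay, trifluoromethyl in place of fluoro on an aromatic carbon, meta to a large group, gave a 1.6-fold higher number from compound 2 to compound 4 (0.21 log units; within the scatter), so this pair cannot be told apart. The change therefore did not carry over with the same result from one core to the other in this assay: the same change on two cores in this assay, a 5.7-fold lower number (0.76 log units; beyond the scatter) from compound 1 to compound 3 and a 1.6-fold higher number (0.21 log units; within the scatter) from compound 2 to compound 4, 9.4-fold (0.97 log units) apart, beyond the scatter of two such steps

Within the data shown here, this shows that the step seen on the core of compound 1 is no safe guide to the same change on the core of compound 2, but with only one pair on each core, it does not show why the two steps part, or how the change would behave on any further core.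

The compounds shown leave open whether other groups on the anilide ring, such as a nitrile, a methoxy group or an amine, would also give steps that depend on the core. They also leave open whether replacing the chloro group of the shared core would alter these steps.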